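Aryloxymethyl-imidazoline series: heteroaryl swap at the ortho position

A few compounds are considered here, and "the series" means these few. Any claim that something is new, unique, unknown or untested is made for them only; others in the source may bear on it.

Measured compounds in a functional assay for activation of Alpha-1D adrenergic receptor (Homo sapiens), read by calcium flux; a higher number here means that more compound is needed for the effect, a lower number that less compound is needed:
- compound 1, `c1ccc(-c2ccncc2)c(OCC2=NCCN2)c1`, < 100000 nM (a limit, not a number)
- compound 2, `c1ccc(-c2cnccn2)c(OCC2=NCCN2)c1`, < 100000 nM (a limit, not a number)
- compound 3, `c1ccc(-c2cc[nH]n2)c(OCC2=NCCN2)c1`, < 100000 nM (a limit, not a number)

Compound 3 stands only on a limit in this assay. The two other values shown are limits of the same kind, so compound 3 cannot be ranked against compound 1 or compound 2; all three sit at the limit of < 100000 nM in this assay, at which 3 of the 3 values shown sit.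

The measured steps give no size: a step that the two limits leave unreadable from compound 1 to compound 2, a step that the two limits leave unreadable from compound 1 to compound 3 and a step that the two limits leave unreadable from compound 2 to compound 3 are each unreadable because the two values at their ends are both limits (the limit of < 100000 nM in this assay, at which 3 of the 3 values shown sit).

Compound 4, `c1ccc(-c2nccs2)c(OCC2=NCCN2)c1`, is not yet measured. Its change from compound 3 is 1,3-thiazol-2-yl in place of 1H-pyrazol-3-yl on an aromatic carbon. Among the compounds with values here, the three measured steps all concern exchanges of the same heteroaryl on the same aromatic carbon, so they are the steps that bear on this change, but none of them shows a readable size, and no direction beyond the scatter can be drawn from them in this assay.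

Compound 4 is therefore expected to behave like the three measured compounds, most likely returning a limit rather than a number; the estimate for compound 4 is 20000 nM (range 1000 nM to 100000 nM). The step this estimate implies, a step that the limit leaves unreadable from compound 3 to compound 4, is expected to be indistinguishable from no change.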

Compound 4, half-maximal effective concentration: 31.6 nM
For compound 4 the middle estimate is 630-fold (2.80 log units) above the measured one; the measured number lies below the stated range.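

No size can be read for the steps to compound 4 from compound 1, compound 2 or compound 3, because each of those three compounds stands only on a limit in this assay: the limit of < 100000 nM in this assay, at which 3 of the 4 values shown sit.

The compounds shown leave open where compound 1, compound 2 and compound 3 lie as numbers, and so how large the exchange for 1,3-thiazol-2-yl is.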